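Chloro on the 4-nitrophenyl ring: working notes

The source may report more compounds than this note shows. Statements on the series, on what has been measured and on what is new or still open speak of the compounds shown alone.

- compound 1 `COc1cc(/C=C(/Sc2ccc(Br)cc2)C(=O)c2ccc(Br)cc2)ccc1O`: 1000 nM
- compound 2 `O=C(/C(=C\c1ccc([N+](=O)[O-])c(O)c1)SCc1ccc(Br)cc1)c1ccc([N+](=O)[O-])cc1`: 1000 nM
- compound 3 `COc1ccccc1/C=C(/SCc1ccc(Cl)c(Cl)c1)C(=O)c1ccc(Cl)cc1`: 10000 nM

All three values come from a functional assay on DU-145 cells (Homo sapiens) for inhibition, read by trypan blue exclusion, with a stated time of 96 h; a higher number here means a weaker inhibitor of growth, a lower number a stronger inhibitor of growth. Among the compounds with values here, compound 2 stands level with compound 1, within the scatter, at the low end of the numbers so far. Compound 3 carries a higher number, beyond the scatter of both.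

The next compound is compound 4 `O=C(/C(=C\c1ccc([N+](=O)[O-])c(O)c1)SCc1ccc(Br)cc1)c1ccc([N+](=O)[O-])c(Cl)c1`. It differs from compound 2 by chloro in place of hydrogen on an aromatic carbon, ortho to a nitro group, so that 4-nitrophenyl becomes 3-chloro-4-nitrophenyl. Within the data shown here, no measured pair isolates this change, so the data give no direct precedent for it. The expectation therefore rests on compound 2 at 1000 nM and on the small size of the change. The step expected in this assay is no change at the digits printed from compound 2 to compound 4 (within the scatter), with nothing expected beyond the scatter in either direction. The estimated value for compound 4 is 1000 nM, with an expected range of 300 nM to 3000 nM.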

Compound 4, concentration for 50% growth inhibition: 1000 nM
For compound 4 middle estimate and measured number coincide at the digits printed, within the range that was stated.
By their numbers in this assay, from the lowest: compounds 1, 2 and 4 (each within the scatter of the next); then compound 3.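

In this assay, within the data shown here, the only single-change pair gives no change at the digits printed from compound 2 to compound 4 (within the scatter), so the 4-nitrophenyl and 3-chloro-4-nitrophenyl forms read alike on this background. Among these compounds, this is the first direct reading at this ring: chloro on this aromatic carbon, ortho to a nitro group, leaves the growth-inhibition number within the scatter, which the earlier compounds could not show because none of them differ in one place. No measurement here bears on why the number holds.

Still open, as far as these compounds go, is whether a larger or different group at this carbon, such as a dimethylamino group or a carboxylic acid, or an amine in place of the nitro group, would hold the number as well. The remaining gaps, including that of compound 3, cannot be read as steps.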